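Methoxycarbonyl in place of chloromethyl on the saturated ring

The source may hold more compounds than are shown below. What is called first, only, known or untested is meant among the compounds shown, and "the series" means these compounds.

Among the compounds with values here, compound 2 `COc1cccc(COc2ccccc2C2=NOC(CCl)C2)c1` gives 66000 nM in an assay with Cystic fibrosis transmembrane conductance regulator (Rattus norvegicus) as the target (on this read-out higher numbers stand for weaker binding and lower numbers for tighter binding), the lowest of the three numbers so far. Compound 1 `COC(=O)C1CC(c2ccccc2OCc2ccc(Br)cc2)=NO1`, which carries a methoxycarbonyl group, gives 73000 nM, within the scatter of compound 2. Within the data shown here, compound 3 `COc1cccc(COc2ccccc2-c2cc(CCO)on2)c1` gives 177000 nM; the only measured step, a 2.7-fold higher number from compound 2 to compound 3 (0.43 log units; beyond the scatter), exchanges the ring itself and does not bear on the change at hand. Compound 4 `COC(=O)C1CC(c2ccccc2OCc2cccc(OC)c2)=NO1` differs from compound 2 by methoxycarbonyl in place of chloromethyl on a saturated ring carbon. Among the measured compounds shown here, no measured step covers this exchange; the values of compound 1 and compound 2 show that a methoxycarbonyl group sits with a number close to that of the chloromethyl group. The step is therefore expected to be a 1.1-fold higher number from compound 2 to compound 4 (0.03 log units; within the scatter), within the scatter. Compound 4 is estimated at 70000 nM, between 30000 nM and 170000 nM.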

Compound 4, dissociation constant: 110000 nM
Compound 4: the middle estimate sits 1.6-fold (0.20 log units) below what was measured; measured number inside the range.
By their numbers in this assay, from the lowest: compounds 2, 1, 4 and 3 (each within the scatter of the next, the first and the last beyond it).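

With methoxycarbonyl in place of chloromethyl on the saturated ring carbon next to the ring oxygen, this assay shows a 1.7-fold higher number from compound 2 to compound 4 (0.22 log units; within the scatter) and so the two groups cannot be told apart at this position. With methoxycarbonyl held there, 3-methoxyphenyl in place of 4-bromophenyl gives a 1.5-fold higher number from compound 1 to compound 4 (0.18 log units; within the scatter) and this exchange separates the two compounds no better. Nothing available accounts for these numbers.

Going by these compounds, whether a carboxylic acid, a primary amide or an amine on this ring carbon would separate from these groups remains open. So does whether any such group would move the number beyond the scatter toward tighter binding.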